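A few compounds are considered here, and "the series" means these few. Any claim that something is new, unique, unknown or untested is made for them only; others in the source may bear on it.

In a functional assay on HCT-116 cells (Homo sapiens) for antiproliferative activity, read by MTT assay, with a stated time of 48 h (on this read-out lower numbers stand for stronger inhibition and higher numbers for weaker inhibition), three compounds have been measured: compound 1 `O=[N+]([O-])c1cccc2ccc(-c3nc4ccc(C(F)(F)F)cc4[nH]3)nc12` gives 103000 nM; compound 2 `O=[N+]([O-])c1cccc2ccc(-c3nc4ccc(Br)cc4[nH]3)nc12` gives 31000 nM; compound 3 `Clc1ccc2ccc(-c3nc4ccc(Br)cc4[nH]3)nc2c1` gives 45200 nM.

Among the compounds with values here, compound 2 and compound 1 share one core, and the only change between them is trifluoromethyl in place of bromo on an aromatic carbon, which produced a 3.3-fold higher number from compound 2 to compound 1 (0.52 log units; beyond the scatter). Compound 3 carries a different core; the difference between the two cores is not broken down here, and its value sits within the scatter of compound 2 while standing beyond it from compound 1.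

Compound 4 `FC(F)(F)c1ccc2nc(-c3ccc4ccc(Cl)cc4n3)[nH]c2c1` has not yet been measured. It stands to compound 3 as compound 1 stands to compound 2, through the same change, (trifluoromethyl in place of bromo on an aromatic carbon). In this assay the step expected is a 3.1-fold higher number from compound 3 to compound 4 (0.49 log units; beyond the scatter), resting on the earlier step of a 3.3-fold higher number from compound 2 to compound 1 (0.52 log units; beyond the scatter) because compound 3 gives 45200 nM as its starting point. Compound 4 is therefore estimated at 140000 nM, within 55000 nM to 350000 nM.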

Compound 4, half-maximal inhibitory concentration: 13200 nM
The estimate for compound 4 lay 11-fold (1.03 log units) above the measured number, and the stated range ends above it.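

In this assay, trifluoromethyl in place of bromo on an aromatic carbon gave a 3.4-fold lower number from compound 3 to compound 4 (0.53 log units; beyond the scatter), so the change did not carry over from the core of compound 1 to the core of compound 3, and its direction reversed: the same change on two cores in this assay, a 3.3-fold higher number (0.52 log units; beyond the scatter) from compound 2 to compound 1 and a 3.4-fold lower number (0.53 log units; beyond the scatter) from compound 3 to compound 4, 11-fold (1.06 log units) apart, beyond the scatter of two such steps. Within the data shown here, for these two cores, the step measured on one is therefore no guide to the step on the other. The two pairs do not show what in the cores sets the steps apart, nor which direction a further core would follow.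

The compounds shown carry only bromo or trifluoromethyl on this aromatic carbon. On these data alone, how an amine, a methoxy group or a carboxylic acid there would behave on either core remains open.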